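A few compounds are considered here, and "the series" means these few. Any claim that something is new, unique, unknown or untested is made for them only; others in the source may bear on it.

In a functional assay (aorta) with Rattus norvegicus as the target, in the presence of a further agent that is not named here (a higher number here means that more compound is needed for the effect, a lower number that less compound is needed), compound 3 `COC(=O)C1=C(C)N=C(C)/C(=C(/O)OC)C1c1ccccc1OCc1c(C(N)=O)no[n+]1[O-]` gives 560 nM, the highest of the three numbers, against compound 2 `COC(=O)C1=C(C)N=C(C)/C(=C(/O)OC)C1c1ccccc1OCc1c(C)no[n+]1[O-]` at 78 nM and compound 1 `COC(=O)C1=C(C)N=C(C)/C(=C(/O)OC)C1c1ccccc1OCCO[N+](=O)[O-]` at 56 nM. Compound 4 `COC(=O)C1=C(C)N=C(C)/C(=C(/O)OC)C1c1ccccc1OCc1no[n+]([O-])c1C(N)=O` has the same atoms as compound 3, joined differently: a group of 9 heavy atoms (3 carbon, 3 nitrogen, 3 oxygen; one five-membered aromatic ring with 3 hetero atoms) in place of a group of 9 heavy atoms (3 carbon, 3 nitrogen, 3 oxygen; one five-membered aromatic ring with 3 hetero atoms), on a saturated chain carbon bound to an oxygen on an aromatic ring. Among the compounds with values here, no measured step isolates such a rearrangement. The closest evidence is a 7.2-fold higher number from compound 2 to compound 3 (0.86 log units; beyond the scatter), for carbamoyl in place of methyl on an aromatic carbon. Also relevant are a 10-fold higher number from compound 1 to compound 3 (1.00 log units; beyond the scatter) and a 1.4-fold higher number from compound 1 to compound 2 (0.14 log units; within the scatter), the latter within the scatter. These steps suggest that this ring substitution can matter, so a modest shift towards the lower values is tentatively expected. The expected step is a 2.8-fold lower number from compound 3 to compound 4 (0.45 log units; beyond the scatter). Compound 4 is estimated at 200 nM, with an expected range of 55 nM to 700 nM.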

Compound 4, half-maximal effective concentration: 550 nM
Compound 4: the middle estimate sits 2.8-fold (0.44 log units) below what was measured; low and high end bracket the measured number.
By their numbers in this assay, from the lowest: compounds 1 and 2 (each within the scatter of the next); then compounds 4 and 3 (each within the scatter of the next).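

In this assay, rearranging the atoms of the ring group on a saturated chain carbon bound to an oxygen on an aromatic ring leaves the number within the scatter (a 1.0-fold lower number from compound 3 to compound 4 (0.01 log units; within the scatter)). Compound 4 stays well apart from the two smaller groups (a 7.1-fold higher number from compound 2 to compound 4 (0.85 log units; beyond the scatter); a 9.8-fold higher number from compound 1 to compound 4 (0.99 log units; beyond the scatter)), so the higher number seen with compound 3 is not confined to one arrangement of the ring. Nothing at hand speaks to the cause.

From the compounds shown here alone, whether a carboxylic acid or a nitrile in place of carbamoyl would sit nearer compound 2 or compound 3 stays open. So does whether the same rearrangement of the methyl-bearing ring of compound 2 would change its number.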